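Carbamate variation in a selenocyanate series: toward compound 4

The source may report more compounds than this note shows. Statements on the series, on what has been measured and on what is new or still open speak of the compounds shown alone.

Measured so far:
compound 1 `C=CCOC(=O)Nc1ccc([Se]C#N)cc1` gives 24500 nM
compound 2 `N#C[Se]c1ccc(NC(=O)OCc2ccccc2)cc1` gives 13300 nM
compound 3 `N#C[Se]c1ccc(NC(=O)Oc2ccccc2)cc1` gives 11700 nM

All three share the core of compound 1 and differ only in the group on the oxygen next to the carbonyl group. In a functional assay on HT-29 cells (Homo sapiens) for cytotoxicity, read by MTT assay, with a stated time of 72 h (on this read-out higher numbers stand for weaker inhibition of growth and lower numbers for stronger inhibition of growth), compound 3 stands at the lowest of the three numbers; its nearest neighbour is compound 2, whose number lies within the scatter of that of compound 3, so no order between these two can be claimed. The furthest is compound 1: the step of a 2.1-fold lower number from compound 1 to compound 3 (0.32 log units; beyond the scatter) is modest but beyond the scatter, whereas a 1.8-fold lower number from compound 1 to compound 2 (0.27 log units; within the scatter) stays within it.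

Compound 4 `CCCCOC(=O)Nc1ccc([Se]C#N)cc1` differs from compound 3 by butyl in place of phenyl on an oxygen next to a carbonyl group. Within the data shown here, the step that bears on it is the one from compound 1 to compound 3, where a chain gave way to phenyl; compound 4 runs that exchange backwards, from phenyl to a chain, though butyl is not allyl. The expectation is therefore a modest rise in number, roughly the reverse of a 2.1-fold lower number from compound 1 to compound 3 (0.32 log units; beyond the scatter), with the chance that, as in the step from compound 1 to compound 2, the change falls within the scatter.

Compound 4 is expected to give about 20000 nM, with a range from 9000 nM to 45000 nM. The estimated step is a 1.7-fold higher number from compound 3 to compound 4 (0.23 log units; within the scatter).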

Compound 4, concentration for 50% growth inhibition: 8100 nM
For compound 4 the middle estimate is 2.5-fold (0.39 log units) above the measured one; measured number below the stated range.
By their numbers in this assay, from the lowest: compounds 4, 3, 2 and 1 (each within the scatter of the next, the first and the last beyond it).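

In this assay a ring is not required at this place, on an oxygen next to a carbonyl group: butyl, with no ring, gives a 1.4-fold lower number from compound 3 to compound 4 (0.16 log units; within the scatter) and, against the other ring-bearing member, a 1.6-fold lower number from compound 2 to compound 4 (0.22 log units; within the scatter). The earlier gap between compound 1 and compound 3 could have been read as chain against ring, but a 3.0-fold lower number from compound 1 to compound 4 (0.48 log units; beyond the scatter) now sets compound 1 apart from a compound that also carries an open chain, so that reading does not hold for these four compounds. No measurement here explains why the allyl and butyl compounds lie apart.

Compound 1 and compound 4 differ in both chain length and the double bond, so a propyl group would be needed to tell these two changes apart. On these data alone, it also remains open whether a longer chain such as octyl, a branched chain such as tert-butyl, or a butyl chain ending in an amine or a carboxylic acid would keep the number in this range.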